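Swapping the Benzyl Substituent Under a Cytotoxicity Limit

The source may hold more compounds than are shown below. What is called first, only, known or untested is meant among the compounds shown, and "the series" means these compounds.

Three compounds have been examined in a toxicity assay on NIH3T3 cells (Mus musculus) for cytotoxicity, read by resazurin assay; a lower number here means that less compound is needed, a higher number that more compound is needed for the effect. Compound 1 `COC(=O)c1ccc(NCc2cncn2Cc2cccc(F)c2)cc1-c1ccccc1` gives > 1000 nM, which is a limit of the assay rather than a number. Compound 2 `COC(=O)c1ccc(NCc2cncn2Cc2cccc(C)c2)cc1-c1ccccc1` gives > 10000 nM, again a limit and not a number. Compound 3 `c1ccc(-c2ccc(Cn3cncc3CNc3ccc(N4CCCCC4)c(-c4ccccc4)c3)cc2)cc1`, built on a different core, gives > 1000 nM, also a limit. The change of methyl in place of fluoro on an aromatic carbon yields a step that the two limits leave unreadable from compound 1 to compound 2, so its size cannot be read. Compound 2 thus stands at the limit of > 10000 nM in this assay, at which 1 of the 3 values shown sits, while the other two compounds sit at the limit of > 1000 nM in this assay, at which 2 of the 3 values shown sit.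

Compound 4 `COC(=O)c1ccc(NCc2cncn2Cc2ccccc2C#N)cc1-c1ccccc1` has not yet been measured. Its change from compound 2 is 2-cyanophenyl in place of 3-methylphenyl on a saturated chain carbon bound to an aromatic nitrogen. Going by the values given here, only the unreadable step between the first two compounds bears on this change, and no measured step points either up or down. For compound 4 a step of a number no higher from compound 2 to compound 4 (the limit leaves the size open) is therefore expected, meaning no change beyond the scatter. The estimate for compound 4 is 10000 nM, within 2000 nM to 50000 nM, most likely reported again only as a limit.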

Compound 4, half-maximal effective concentration: 25000 nM
Beside the measured number, compound 4's estimate is 2.5-fold (0.40 log units) below it; measured number inside the range.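

Compound 1 and compound 2 give only limits, so the steps from each of them to compound 4 cannot be read. The compounds shown leave open how far changing the benzyl group on the shared core shifts the cytotoxic concentration.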